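Furan-2-yl on the saturated ring carbon of compound 1

A few compounds are considered here, and "the series" means these few. Any claim that something is new, unique, unknown or untested is made for them only; others in the source may bear on it.

Measured so far:
compound 1 `Cc1ccc(C2C(C#N)=C(N)N(c3ccc(S(N)(=O)=O)cc3)C3=C2C(=O)CCC3)cc1` — 100%
compound 2 `N#CC1=C(N)N(c2ccc(S(N)(=O)=O)cc2)C2=C(C(=O)CCC2)C1/C=C/c1ccccc1` — 45%
compound 3 `COc1ccc(C2C(C#N)=C(N)N(c3ccc(S(N)(=O)=O)cc3)C3=C2C(=O)CCC3)cc1` — 100%

In a functional assay on Ehrlich cells (Mus musculus) for antiproliferative activity, read by trypan blue exclusion, with a stated time of 2 h, tested at 100 ug/mL (a lower number here means a weaker effect, a higher number a stronger effect of the compound at the concentration tested), compound 1 gives 100%, level with compound 3 at the digits printed; the two share the highest reading of the three. Among the measured compounds shown here, the only number clearly apart is that of compound 2, which in this assay gives 45%, and the step of a number 55 percentage points lower from compound 1 to compound 2 (beyond the scatter) is large. The reverse move, a number 55 percentage points higher from compound 2 to compound 3 (beyond the scatter), is equally large, whereas no change at the digits printed from compound 1 to compound 3 (within the scatter) shows that exchanging the substituent on the aromatic ring leaves the reading where it is.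

Compound 4 `N#CC1=C(N)N(c2ccc(S(N)(=O)=O)cc2)C2=C(C(=O)CCC2)C1c1ccco1` has not yet been measured in this assay. It differs from compound 1 in one place: furan-2-yl in place of 4-methylphenyl on a saturated ring carbon. For the measured compounds named here, the steps that bear on this change are those at the same saturated ring carbon. They show that the large drop followed replacing an aromatic ring by 2-phenylethenyl, while an aromatic ring with a different substituent gave no change. Furan-2-yl is again an aromatic ring on that carbon, so no step beyond the scatter is expected, with at most a modest fall allowed for the smaller ring.

Compound 4 is therefore expected to give about 88%, within 60% to 100%, which means an estimated step of a number 12 percentage points lower from compound 1 to compound 4 (beyond the scatter).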

Compound 4, a percentage reported as activity, at one concentration (the size of the read-out at that concentration, not a potency): 10%
Compound 4: middle estimate off by 78 percentage points, on the high side, outside the stated range (below it).
By their numbers in this assay, from the lowest: compound 4; then compound 2; then compounds 1 and 3 (each within the scatter of the next).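

In this assay, among the compounds shown here, the earlier compounds left open whether any aromatic ring on this saturated ring carbon would preserve the reading, and furan-2-yl shows that it does not: exchanging either six-membered aromatic ring of carbon only for this five-membered aromatic ring with one hetero atom gives a number 90 percentage points lower from compound 1 to compound 4 (beyond the scatter) and a number 90 percentage points lower from compound 3 to compound 4 (beyond the scatter). The position therefore tolerates a change of substituent on the 4-substituted phenyl ring far better than a change of the ring itself, and aromatic against non-aromatic does not sort the groups here, since the step to furan-2-yl from 2-phenylethenyl is a number 35 percentage points lower from compound 2 to compound 4 (beyond the scatter), with compound 2 going against any such division. Nothing available accounts for this fall.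

The change to furan-2-yl alters ring size, hetero atom and the para-type substituent's absence all at once, so the compounds shown cannot say which of these carries the loss. An unsubstituted phenyl, a thiophen-2-yl or a furan-3-yl on the same carbon would begin to separate them, and a pyridin-3-yl would test a six-membered ring that contains a hetero atom.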